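The source may hold more compounds than are shown below. What is called first, only, known or untested is meant among the compounds shown, and "the series" means these compounds.

Measured so far in an assay on CHO cells for inhibition of Glucagon receptor (Homo sapiens), tested at 20 uM; on this read-out lower numbers stand for less inhibition and higher numbers for more inhibition at the one concentration tested (going by the name of the read-out):
compound 1 `CCCCCc1c(C(C)C)nc(C(C)C)c(CO)c1-c1ccccc1OC` — 27%
compound 2 `CCCCCc1c(C(C)C)nc(C(C)C)c(CO)c1-c1cccc(C)c1` — 46%
compound 3 `CCCCCc1c(C(C)C)nc(C(C)C)c(CO)c1-c1ccc(Cl)cc1Cl` — 8%

Compound 1 is second highest of the three numbers in this assay; compound 2 lies above it by a number 19 percentage points higher from compound 1 to compound 2 (beyond the scatter), compound 3 below it by a number 19 percentage points lower from compound 1 to compound 3 (beyond the scatter). The pair of compound 2 and compound 3 spans a number 38 percentage points lower from compound 2 to compound 3 (beyond the scatter).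

Compound 4 `CCCCCc1c(C(C)C)nc(C(C)C)c(CO)c1-c1ccccc1NC(C)=O` is not yet measured. It differs from compound 1 by acetamido in place of methoxy on an aromatic carbon.

Both measured steps from compound 1 change the substituent on the same phenyl ring and are modest, one in each direction. For the measured compounds named here, neither swaps a methoxy for an acetamido, so no step bears directly on the change to compound 4. The expected step of a number 2 percentage points lower from compound 1 to compound 4 (within the scatter) is therefore small and of uncertain direction. Compound 4 is estimated at 25% in this assay, expected to fall between 8% and 45%.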

Compound 4, a percentage reported as inhibition, at one concentration (the size of the read-out at that concentration, not a potency): 13%
Compound 4: the middle estimate sits 12 percentage points above what was measured, and the stated range covers the measured number.
By their numbers in this assay, from the lowest: compounds 3 and 4 (each within the scatter of the next); then compound 1; then compound 2.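

In this assay, acetamido in place of methoxy on an aromatic carbon, ortho to a large group, gives a number 14 percentage points lower from compound 1 to compound 4 (beyond the scatter). Unlike the earlier steps from compound 1, this one leaves the substituent at the same place and changes only the group, so the read-out is shown to respond to the group at this place alone. The data at hand offer no explanation for this step.

On these data alone, whether a hydroxyl or an amino group at this place would keep or raise the number remains open. So does whether the step follows the amide hydrogen or the larger group as a whole.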